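The compounds below may be only part of what the source reports. "The series", "measured", "known", "first", "only" and "open" are said of these compounds alone.

Working notes on the series. Compound 1 `Cc1c(CO)c(CO)c2n1[C@@H](c1ccccc1)SC2`, compound 2 `OCc1cn2c(c1CO)CS[C@@H]2c1ccccc1` and compound 3 `OCc1c(CO)c(-c2ccccc2)n2c1CS[C@@H]2c1ccccc1` share one core and differ only in the group on one aromatic carbon of that core. In a functional assay on MCF7 cells (Homo sapiens) for cytotoxicity, read by MTT assay, with a stated time of 48 h (a lower number here means a stronger inhibitor, a higher number a weaker inhibitor), compound 1 gives 1900 nM, while in this assay compound 2 gives 19400 nM and compound 3 gives 61800 nM. The measured steps are a 10-fold higher number from compound 1 to compound 2 (1.01 log units; beyond the scatter), a 33-fold higher number from compound 1 to compound 3 (1.51 log units; beyond the scatter) and a 3.2-fold higher number from compound 2 to compound 3 (0.50 log units; beyond the scatter). Compound 3 therefore stands highest of the three numbers, with compound 2 nearest and compound 1 furthest away.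

Compound 4 `OCc1c(CO)c(-c2ccc(F)cc2)n2c1CS[C@@H]2c1ccccc1` is not yet measured. It differs from compound 3 by fluoro in place of hydrogen on an aromatic carbon, so the change is fluoro in place of hydrogen on an aromatic carbon of a six-membered aromatic ring of carbon only, para to a large group; read one bond further out, phenyl becomes 4-fluorophenyl. Within the data shown here, none of the three measured steps bears on this change: each of them alters the group on the core carbon, and no compound so far carries a substituent on that phenyl ring. Among the measured compounds shown here, with no step to lean on, the expectation in this assay is no change beyond the scatter, in either direction. The expected step is a 1.0-fold lower number from compound 3 to compound 4 (0.01 log units; within the scatter). For compound 4 the estimate is 60000 nM, with a range from 25000 nM to 150000 nM.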

Compound 4, half-maximal inhibitory concentration: 46300 nM
The estimate for compound 4 lay 1.3-fold (0.11 log units) above the measured number, within the range that was stated.
By their numbers in this assay, from the lowest: compound 1; then compound 2; then compounds 4 and 3 (each within the scatter of the next).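

In this assay, the series now has its first substituent on the phenyl ring: fluoro in place of hydrogen on an aromatic carbon, para to a large group, gives a 1.3-fold lower number from compound 3 to compound 4 (0.13 log units; within the scatter) and so does not separate the two compounds. The placing of the aryl compounds seen with phenyl also holds with 4-fluorophenyl on the core carbon, which gives a 2.4-fold higher number from compound 2 to compound 4 (0.38 log units; beyond the scatter) and a 24-fold higher number from compound 1 to compound 4 (1.39 log units; beyond the scatter) so that, across compounds 1 to 4, methyl on that carbon still gives the lowest number and an aryl group a higher number than hydrogen. No measurement at hand accounts for either the result at the para carbon or the gaps between the groups on the core carbon.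

Going by these compounds, a single fluoro says little about this para carbon as a whole, and whether an amine, a carboxylic acid or a methoxy group there would move the number beyond the scatter remains open. Also open, on these data alone, is whether a longer chain such as ethyl, in place of the methyl of compound 1, would give a lower number than that compound does.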